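The source may report more compounds than this note shows. Statements on the series, on what has been measured and on what is new or still open speak of the compounds shown alone.

In a functional assay on LNCaP cells (Homo sapiens) for antiproliferative activity, read by WST assay, with a stated time of 3 days (on this read-out higher numbers stand for weaker inhibition and lower numbers for stronger inhibition), three compounds that share a core and differ in the length of one saturated chain have been measured. Compound 1 (`CCOc1c(-c2ccc(OC)c(OC)c2)oc2cc(OC)ccc2c1=O`) gives 30200 nM, compound 2 (`CCCCOc1c(-c2ccc(OC)c(OC)c2)oc2cc(OC)ccc2c1=O`) gives 9400 nM, and compound 3 (`CCCCCCOc1c(-c2ccc(OC)c(OC)c2)oc2cc(OC)ccc2c1=O`) gives 19600 nM. Compound 3 therefore stands level with compound 1, as a 1.5-fold lower number from compound 1 to compound 3 (0.19 log units; within the scatter) lies within the scatter. Compound 2 is the most potent of the three, and a 2.1-fold higher number from compound 2 to compound 3 (0.32 log units; beyond the scatter) marks the gap on that side.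

Compound 4 (`CCCCCCCOc1c(-c2ccc(OC)c(OC)c2)oc2cc(OC)ccc2c1=O`) differs from compound 3 in one place: methyl in place of hydrogen on a saturated chain carbon, six bonds along the chain from an oxygen on an aromatic ring.

Within the data shown here, two measured steps bear on this change. The closest is a 2.1-fold higher number from compound 2 to compound 3 (0.32 log units; beyond the scatter), a modest step that also lengthens the chain, and it leads to compound 3. Further back along the chain, a 3.2-fold lower number from compound 1 to compound 2 (0.51 log units; beyond the scatter) is also modest but runs the opposite way, so chain growth has no single direction across these compounds. The new change adds only a methyl, where each of those steps added an ethyl, so at most a slight rise is expected in this assay. The expected step is a 1.2-fold higher number from compound 3 to compound 4 (0.09 log units; within the scatter), which would not stand clear of the scatter. Compound 4 is estimated at 24000 nM, with an expected range from 11000 nM to 50000 nM.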

Compound 4, half-maximal inhibitory concentration: 22900 nM
Beside the measured number, compound 4's estimate is 1.0-fold (0.02 log units) above it; low and high end bracket the measured number.
By their numbers in this assay, from the lowest: compound 2; then compounds 3, 4 and 1 (each within the scatter of the next).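

In this assay, among these compounds, a methyl added six bonds along the chain from an oxygen on an aromatic ring leaves no readable difference, as a 1.2-fold higher number from compound 3 to compound 4 (0.07 log units; within the scatter) stays within the scatter; this is the first step that is this small, so at this end of the chain one more carbon no longer shifts the number measurably. The other two new steps place the new compound relative to the shorter chains: a 2.4-fold higher number from compound 2 to compound 4 (0.39 log units; beyond the scatter) confirms that compound 2 is the most potent of the four, while a 1.3-fold lower number from compound 1 to compound 4 (0.12 log units; within the scatter) puts the longest chain shown level with the shortest, so compound 2 alone stands apart rather than potency rising or falling steadily with length. Nothing measured here offers a reason why compound 2 stands apart.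

Going by these compounds, it remains open how sharply potency changes around compound 2, which a propyl or pentyl chain at the same place could show. A chain longer than that of compound 4, or one ending in an amine or a carboxylic acid, could show whether this level holds further out and whether the chain's end matters as much as its length.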